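A few compounds are considered here, and "the series" means these few. Any claim that something is new, unique, unknown or untested is made for them only; others in the source may bear on it.

Three compounds have been measured in a physicochemical assay for solubility, measured as kinetic solubility, at pH 2; a higher number here means a more soluble compound, a lower number a less soluble compound:

Compound 1 `CC(C)c1noc(-c2cccc(CNc3ccc4[nH]nc(C(=O)O)c4c3)c2O)n1`: 11000 nM
Compound 2 `CC(C)c1csc(-c2cccc(CN(C)c3ccc4[nH]nc(C(=O)O)c4c3)c2O)n1`: 175000 nM
Compound 3 `CN(C)c1noc(-c2cccc(CNc3cnc4nn[nH]c4c3)c2O)n1`: 530 nM

Among these three numbers, compound 1 stands second highest. Its nearest neighbour is compound 2, whose number is higher by an amount beyond the usual scatter, and its furthest is compound 3, whose number is lower, again beyond the scatter. All three compounds differ from one another in more than one place, so none of these gaps can be pinned on a single change.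

Compound 4 `CC(C)c1coc(-c2cccc(CNc3ccc4[nH]nc(C(=O)O)c4c3)c2O)n1` has not yet been measured. It differs from compound 1 in one place only: 4-isopropyl-1,3-oxazol-2-yl in place of 3-isopropyl-1,2,4-oxadiazol-5-yl on an aromatic carbon. The change keeps the size of the group and its position on the ring; what changes is the ring itself, with one fewer hetero atom and one fewer hydrogen-bond acceptor.

Going by the values given here, no measured pair shows this change, so any expectation rests on the size of the swap alone. A small step is expected, if any, and more likely downward than upward, with the result probably within the scatter of compound 1 at 11000 nM. The expected step from compound 1 to compound 4 is a 1.5-fold lower number from compound 1 to compound 4 (0.17 log units; within the scatter). For compound 4 the estimate in this assay is 7500 nM, with a range from 2500 nM to 25000 nM.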

Compound 4, solubility: 4000 nM
The estimate for compound 4 lay 1.9-fold (0.27 log units) above the measured number; measured number inside the range.
By their numbers in this assay, from the lowest: compound 3; then compound 4; then compound 1; then compound 2.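

In this assay, replacing 3-isopropyl-1,2,4-oxadiazol-5-yl with 4-isopropyl-1,3-oxazol-2-yl gives a modest step (a 2.8-fold lower number from compound 1 to compound 4 (0.44 log units; beyond the scatter)) that lies beyond the usual scatter, so this place, on an aromatic carbon ortho to a hydroxy group, responds to the identity of the ring even though the heavy-atom count stays the same. Going by these compounds alone, this is the first pair here that differs in one place only, which means a gap in this set can now be tied to a single change: a ring with one fewer hetero atom and one fewer hydrogen-bond acceptor, carbon having taken the place of nitrogen. Nothing on hand explains the lower number, and this pair alone cannot separate the lost acceptor from any other difference between the two rings.

Going by these compounds, whether the step keeps its direction and size on another core, such as that of compound 3, remains open, since it has been read only once, on the core of compound 1. Also open, on these data alone, is how a 1,3,4-oxadiazole ring, or a cyclopropyl or tert-butyl group in place of the isopropyl, would behave at this same place.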